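Substituent survey on the shared core: notes before compound 4

The source may hold more compounds than are shown below. What is called first, only, known or untested is meant among the compounds shown, and "the series" means these compounds.

Measured so far, in an assay on LM cells for displacement of a labelled ligand from Neuropeptide Y receptor type 5 (Homo sapiens); a higher number here means a weaker inhibitor, a lower number a stronger inhibitor:
- compound 1 `Fc1ccc(C2(c3ccc(F)cc3)CNC(c3ccccc3)=N2)cc1`: compound 1 gives 32 nM
- compound 2 `Fc1ccc(C2(c3ccc(F)cc3)CNC(c3cccc(Cl)c3)=N2)cc1`: compound 2 gives 5.4 nM
- compound 3 `Cc1cccc(C2=NC(c3ccc(F)cc3)(c3ccc(F)cc3)CN2)c1`: compound 3 gives 30 nM

Compound 1 holds the highest of the three numbers in this assay; compound 3 sits within the scatter of it, and compound 2 is the only one clearly apart, with a 5.9-fold lower number from compound 1 to compound 2 (0.77 log units; beyond the scatter). Compound 4 `CN(C)c1cccc(C2=NC(c3ccc(F)cc3)(c3ccc(F)cc3)CN2)c1` differs from compound 1 by dimethylamino in place of hydrogen on an aromatic carbon. The two measured steps that start from compound 1 bear on it directly, since both put a small group at the same place: chloro gave a 5.9-fold lower number from compound 1 to compound 2 (0.77 log units; beyond the scatter), whereas methyl gave a 1.1-fold lower number from compound 1 to compound 3 (0.03 log units; within the scatter). Between themselves the two substituted compounds differ by a 5.6-fold higher number from compound 2 to compound 3 (0.74 log units; beyond the scatter). So one substituent at this place moved the number by a modest amount and another left it untouched; no step with dimethylamino, or with any group carrying a hydrogen-bond acceptor, is available. The expected step of a 1.1-fold higher number from compound 1 to compound 4 (0.04 log units; within the scatter) in this assay is therefore small, without a clear direction beyond the scatter. The estimate for compound 4 in this assay is 35 nM, with a range from 9 nM to 140 nM.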

Compound 4, half-maximal inhibitory concentration: > 1000 nM
Compound 4: a limit, no number; the forecaster's own chance of this, stated with the estimate: 3%; at least 28-fold (1.45 log units) between middle value and limit.
By their numbers in this assay, from the lowest: compound 2; then compounds 3 and 1 (each within the scatter of the next). At a limit, above all of these: compound 4.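

Compound 4 is read as a limit and not as a number: the limit of > 1000 nM in this assay, at which 1 of the 4 values shown sits.

At this place, on an aromatic carbon and meta to a large group, dimethylamino gives an at least 31-fold higher number from compound 1 to compound 4 (1.49 log units; beyond the scatter), an at least 33-fold higher number from compound 3 to compound 4 (1.52 log units; beyond the scatter) and an at least 180-fold higher number from compound 2 to compound 4 (2.26 log units; beyond the scatter). Chloro and methyl had shown only a lower number or no change beyond the scatter, so this is the first sign that a change at this place can also raise the number, and by a large step.

The compounds shown do not tell whether the rise follows the nitrogen or the two methyl groups on it. From the compounds shown here alone, an unsubstituted amine, a methoxy group or a longer alkyl chain at the same place would bear on that, and the true size of the steps stays open behind the limit.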